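The source may report more compounds than this note shows. Statements on the series, on what has been measured and on what is new or still open speak of the compounds shown alone.

Measured compounds:
- compound 1, `CCOC1=CC(=O)c2ccccc2C1=O`: 16900 nM
- compound 2, `O=C(Oc1ccc2c(c1)C(=O)C=CC2=O)c1ccccc1`: 12100 nM
- compound 3, `CC(=O)Oc1ccc2c(c1)C(=O)C=CC2=O`: 22100 nM

Three compounds built on a shared quinone core were tested in a functional assay on KB cells (Homo sapiens) for cytotoxicity; on this read-out lower numbers stand for stronger inhibition and higher numbers for weaker inhibition. Compound 1 gives 16900 nM, compound 2 gives 12100 nM and compound 3 gives 22100 nM. Compound 1 stands second highest of the three numbers, but all three lie within the usual scatter of one another, so no real ordering can be read from them.

For the measured compounds named here, the only single-point comparison available is from compound 2 to compound 3, where the change is methyl in place of phenyl on a carbonyl carbon: a 1.8-fold higher number from compound 2 to compound 3 (0.26 log units; within the scatter). That comparison concerns an ester on a different position of the core and does not touch the ethoxy group of compound 1.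

Compound 4, `CS(=O)(=O)OC1=CC(=O)c2ccccc2C1=O`, has not yet been measured in this assay . It differs from compound 1 in this way: methylsulfonyl in place of ethyl on an oxygen on an unsaturated carbon. Going by the values given here, no measured pair shows what replacing an alkyl group on that oxygen by methylsulfonyl does. Given that every change seen so far stayed within the scatter, compound 4 is expected to give a number close to that of compound 1, with the step of a 1.1-fold lower number from compound 1 to compound 4 (0.05 log units; within the scatter) expected to be no larger than the scatter. Compound 4 is therefore estimated at 15000 nM, with a plausible range from 5000 nM to 45000 nM.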

Compound 4, half-maximal inhibitory concentration: 7180 nM
Compound 4: the middle estimate sits 2.1-fold (0.32 log units) above what was measured, within the range that was stated.
By their numbers in this assay, from the lowest: compounds 4, 2, 1 and 3 (each within the scatter of the next, the first and the last beyond it).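

In this assay, putting methylsulfonyl in place of ethyl on this oxygen gives a 2.4-fold lower number from compound 1 to compound 4 (0.37 log units; beyond the scatter), a modest change, but the first in this set to lie beyond the scatter. For the compounds shown here, the one earlier step, a 1.8-fold higher number from compound 2 to compound 3 (0.26 log units; within the scatter), concerned a different group and stayed within the scatter, so it could not show whether any group on the shared core affects the number; this result shows that the group on the oxygen of compound 1 does, and that the change from ethoxy to (methylsulfonyl)oxy goes towards stronger inhibition. Nothing available here explains why this swap has that effect.

A single pair at a single place cannot show whether the shift belongs to methylsulfonyl itself or would appear with other replacements for ethyl. From the compounds shown here alone, it remains open how the number would respond to a butyl chain on the oxygen, to a phenylsulfonyl group there, or to an amine in place of the ethoxy group, and such compounds would show whether this modest step is the start of a trend or an isolated result.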